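Hydroxy to Methoxy and Cytotoxicity in Two Cores

The source may hold more compounds than are shown below. What is called first, only, known or untested is meant among the compounds shown, and "the series" means these compounds.

Measured so far:
- compound 1, `O=C(Nc1ccc(Sc2nc3ccccc3s2)c(Cl)c1)c1cc(Br)ccc1O`, gives 45000 nM.
- compound 2, `O=C(Nc1cccc(Cl)c1)c1cc(Br)ccc1O`, gives 15000 nM.
- compound 3, `COc1ccc(Br)cc1C(=O)Nc1ccc(Sc2nc3ccccc3s2)c(Cl)c1`, reaches only a limit of the assay, > 100000 nM.

All three values come from an ADME assay on HEK293 cells (Homo sapiens) for cytotoxicity, read by reporter gene assay and resazurin assay, with a stated time of 48 h; on this read-out higher numbers stand for lower toxicity in this test and lower numbers for higher toxicity in this test. Compound 1 and compound 3 differ in one place, (methyl in place of hydrogen on an oxygen on an aromatic ring), and that change gave an at least 2.2-fold higher number from compound 1 to compound 3 (0.34 log units; beyond the scatter). The size of the step is open at the top because the limit of > 100000 nM in this assay, at which 1 of the 3 values shown sits, caps what can be read for compound 3. Compound 2 carries a smaller core; how it differs from compound 1 is not broken down here. Its value is the lowest of the two plain numbers, with compound 1 standing above it in this assay.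

Compound 4, `COc1ccc(Br)cc1C(=O)Nc1cccc(Cl)c1`, is not yet measured. Against compound 2 it shows (methyl in place of hydrogen on an oxygen on an aromatic ring), the same change that turns compound 1 into compound 3. Starting from the value of compound 2 and resting on the step of an at least 2.2-fold higher number from compound 1 to compound 3 (0.34 log units; beyond the scatter), compound 4 is expected to move by a 2.7-fold higher number from compound 2 to compound 4 (0.43 log units; beyond the scatter). The estimate for compound 4 is therefore 40000 nM, expected to lie between 15000 nM and 120000 nM.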

Compound 4, half-maximal cytotoxic concentration: > 100000 nM
Compound 4 gave a limit, no number; the forecaster's own chance of this, stated with the estimate: 20%; middle value at least 2.5-fold (0.39 log units) away from the limit.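

In this assay, the change from hydroxy to methoxy carries over to the smaller core in its direction: it gave an at least 6.6-fold higher number from compound 2 to compound 4 (0.82 log units; beyond the scatter), so the number rises on both cores shown and neither pair goes against this. Compound 4 gives > 100000 nM, which is a limit of the assay and not a number, and such limits mark both methoxy compounds: the limit of > 100000 nM in this assay, at which 2 of the 4 values shown sit. What this does not show is whether the change is equally large on the two cores, since neither step has a known upper end: the same change on two cores in this assay, an at least 2.2-fold higher number (0.34 log units; beyond the scatter) from compound 1 to compound 3 and an at least 6.6-fold higher number (0.82 log units; beyond the scatter) from compound 2 to compound 4; the limit leaves it open whether they differ.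

The compounds shown carry only hydrogen or methyl on that oxygen, so it stays open how a longer chain such as ethyl, or an amine in place of the hydroxy group, would read in this assay. For the compounds shown here, with only two cores in view, it also stays open whether the same change would raise the number on a third core.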